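Removing a methyl from a pyridine N-oxide catechol

The source may hold more compounds than are shown below. What is called first, only, known or untested is meant among the compounds shown, and "the series" means these compounds.

Measured so far:
compound 1 `O=[N+]([O-])c1cc(-c2nc(-c3ccccc3)no2)cc(O)c1O`, 20.6%
compound 2 `O=[N+]([O-])c1cc(-c2nc(-c3ccc[n+]([O-])c3)no2)cc(O)c1O`, 77%
compound 3 `Cc1ccc(-c2noc(-c3cc(O)c(O)c([N+](=O)[O-])c3)n2)c(Cl)[n+]1[O-]`, 31.6%

In a functional assay on the whole organism (liver, strain Wistar) for inhibition, with Rattus norvegicus as the target, with a stated time of 3 h, at a dose of 3 mg/kg by the oral route (a lower number here means less inhibition, a higher number more inhibition at the dose given (going by the name of the read-out)), compound 3 stands second of the three numbers, above compound 1 and far below compound 2. Compound 4 `O=[N+]([O-])c1cc(-c2nc(-c3ccc[n+]([O-])c3Cl)no2)cc(O)c1O` differs from compound 3 by one change: hydrogen in place of methyl on an aromatic carbon. Among the measured compounds shown here, no measured step covers such a change. For the measured compounds named here, the one step known, a number 56.4 percentage points higher from compound 1 to compound 2 (beyond the scatter), swaps a whole ring and says nothing about a methyl. Going by these compounds, compound 2, which carries neither chloro nor methyl on that ring, gives a far higher number than compound 3, but how much of that gap the methyl accounts for is unknown. A moderate rise, a number 13.4 percentage points higher from compound 3 to compound 4 (beyond the scatter), is therefore expected, with wide uncertainty. Compound 4 is estimated at 45%, between 22% and 70%.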

Compound 4, a percentage reported as inhibition, in the whole organism at one dose (the size of the read-out at that dose, not a potency): 71.6%
Compound 4: middle estimate off by 26.6 percentage points, on the low side, and the stated range ends below it.
By their numbers in this assay, from the lowest: compound 1; then compound 3; then compounds 4 and 2 (each within the scatter of the next).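

In this assay, one methyl on the aromatic carbon next to the ring nitrogen weighs heavily, with a number 40 percentage points higher from compound 3 to compound 4 (beyond the scatter) once hydrogen takes its place. The chloro group on the same ring costs nothing that can be told apart, with a number 5.4 percentage points lower from compound 2 to compound 4 (within the scatter) as the printed step. The gain over the carbon-only ring also survives with chloro present, as a number 51 percentage points higher from compound 1 to compound 4 (beyond the scatter) shows.

Nothing shown here explains why the methyl counts for so much. Going by these compounds, whether an ethyl group, a methoxy group or an amine on this carbon would behave like methyl or like hydrogen stays open.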